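A few compounds are considered here, and "the series" means these few. Any claim that something is new, unique, unknown or untested is made for them only; others in the source may bear on it.

Measured in a functional assay on K562 cells (Homo sapiens) for antiproliferative activity, read by trypan blue exclusion, with a stated time of 48 h, tested at 10 uM; on this read-out higher numbers stand for more inhibition of growth at the one concentration tested and lower numbers for less inhibition of growth:
- compound 1 `Cc1ccc(/C=C/C(=O)Nc2ccc(Cl)cc2C(N)=O)cc1`: 64%
- compound 2 `NC(=O)c1cc(Br)ccc1NC(=O)/C=C/c1ccccc1Cl`: 59%
- compound 3 `NC(=O)c1cc(Br)ccc1NC(=O)/C=C/c1cccc(Cl)c1`: 25.5%

Compound 3, at 25.5%, has the lowest of the three numbers, well under both other compounds. The next compound to consider is compound 4 `NC(=O)c1cc(Br)ccc1NC(=O)/C=C/c1cccc(Br)c1`. It keeps the structure of compound 3 except for one group: bromo in place of chloro on an aromatic carbon. Put simply, this is bromo in place of chloro on an aromatic carbon, a change from 3-chlorophenyl to 3-bromophenyl.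

Within the data shown here, only one measured step bears on this change: a number 33.5 percentage points lower from compound 2 to compound 3 (beyond the scatter). That step is large, but it moves the chloro to another ring carbon, whereas the new change leaves the halogen on the same carbon. Among the measured compounds shown here, no measured step swaps chloro for bromo, so the evidence is thin, and no shift beyond the scatter is expected. The estimated step is a number 4.5 percentage points higher from compound 3 to compound 4 (within the scatter). For compound 4 the expected value is 30%, with an estimated range of 15% to 48%.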

Compound 4, percent growth inhibition at one concentration: 45.9%
The estimate for compound 4 lay 15.9 percentage points below the measured number; the measured number falls inside the stated range.
By their numbers in this assay, from the lowest: compound 3; then compound 4; then compounds 2 and 1 (each within the scatter of the next).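

In this assay the identity of the halogen on this aromatic carbon matters, not only where it sits: replacing chloro with bromo, one heavy atom for one with no change in hydrogen-bond donors or acceptors, gives a number 20.4 percentage points higher from compound 3 to compound 4 (beyond the scatter) and lifts much of the earlier loss. That lift is incomplete, as the 3-bromophenyl group still gives a number 13.1 percentage points lower from compound 2 to compound 4 (beyond the scatter) and so does not fully match the 2-chlorophenyl group. No measurement available here explains the difference between the two halogens.

Still open, as far as these compounds go, is how fluoro, iodo, methoxy or an amine on the same aromatic carbon would compare with chloro and bromo. Also open, from the compounds shown here alone, is whether bromo in place of the chloro of compound 2 would shift the number in the same direction.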